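The source may report more compounds than this note shows. Statements on the series, on what has been measured and on what is new or still open speak of the compounds shown alone.

For the measured compounds named here, compound 3 `COc1c(F)cccc1N1C(=O)CSC1c1cccc(C(=O)NCCCCc2ccccc2)c1` gives 12% in a functional assay on U2OS cells (Homo sapiens) for inhibition, read by CCK-8 assay, with a stated time of 72 h, tested at 1 uM (a higher number here means more inhibition at the concentration tested (going by the name of the read-out), a lower number less inhibition), the lowest of the three numbers measured so far. Compound 1 `O=C(NCCCCc1ccccc1)c1cccc(C2SCC(=O)N2c2cccc(F)c2)c1` gives 39% and compound 2 `O=C(NCCCCc1ccccc1)c1cccc(C2SCC(=O)N2c2ccccc2F)c1` gives 38%; the step of a number 1 percentage points lower from compound 1 to compound 2 (within the scatter) stays within the scatter, whereas a number 27 percentage points lower from compound 1 to compound 3 (beyond the scatter) and a number 26 percentage points lower from compound 2 to compound 3 (beyond the scatter) both go beyond it, each a modest fall. Compound 4 `COc1ccc(N2C(=O)CSC2c2cccc(C(=O)NCCCCc3ccccc3)c2)c(OC)c1` differs from compound 3 in one place: 2,4-dimethoxyphenyl in place of 3-fluoro-2-methoxyphenyl on an amide-type nitrogen in a ring. The two steps that bear on this change are a number 27 percentage points lower from compound 1 to compound 3 (beyond the scatter) and a number 26 percentage points lower from compound 2 to compound 3 (beyond the scatter), and since a methoxy group remains on the ring in compound 4, the step of a number 3 percentage points higher from compound 3 to compound 4 (within the scatter) is expected to stay within the scatter. Compound 4 is therefore estimated at 15%, with a likely range from 0% to 35%.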

Compound 4, a percentage reported as inhibition, at one concentration (the size of the read-out at that concentration, not a potency): 37%
Beside the measured number, compound 4's estimate is 22 percentage points below it; measured number above the stated range.
By their numbers in this assay, from the lowest: compound 3; then compounds 4, 2 and 1 (each within the scatter of the next).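

In this assay, the step of a number 25 percentage points higher from compound 3 to compound 4 (beyond the scatter) shows that a methoxy group on this ring does not by itself go with the low number, for 2,4-dimethoxyphenyl carries methoxy groups too. The fluorine-free 2,4-dimethoxyphenyl also cannot be told apart from the single-fluorine rings, with a number 1 percentage points lower from compound 2 to compound 4 (within the scatter) and a number 2 percentage points lower from compound 1 to compound 4 (within the scatter). No measurement shown explains the low number of compound 3. Still open, going by these compounds, is whether an amine or a carboxylic acid on this ring would shift the number, and whether 4-methoxyphenyl alone would match 2,4-dimethoxyphenyl.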